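Chain change on two cores: a step not yet readable

The compounds below may be only part of what the source reports. "The series", "measured", "known", "first", "only" and "open" are said of these compounds alone.

Compound 1 `COc1cc(/C=C/c2cc(/C=C/c3cc(OC)c(OC)c(OC)c3)nc(OCCCCBr)n2)cc(OC)c1OC` and compound 2 `COc1cc(/C=C/c2cc(/C=C/c3cc(OC)c(OC)c(OC)c3)nc(OCCCCCBr)n2)cc(OC)c1OC` share one core and differ only in the length of the chain ending in bromine. In a functional assay on NCI-H1299 cells (Homo sapiens) for cytotoxicity, read by fluorescence and resazurin assay, with a stated time of 48 h (a higher number here means a weaker inhibitor, a lower number a stronger inhibitor), compound 1 gives a value that is a limit of the measurement, > 20000 nM. In this assay compound 2 likewise gives only a limit, > 20000 nM. The change between the two is bromo in place of bromomethyl on a saturated chain carbon, four bonds along the chain from an oxygen on an aromatic ring, and the step it made, a step that the two limits leave unreadable from compound 2 to compound 1, cannot be read because both ends sit at the limit of > 20000 nM in this assay, at which 3 of the 3 values shown sit.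

Compound 3 `BrCCCCCCOc1nc(/C=C/c2ccccc2)cc(/C=C/c2ccccc2)n1` carries a different core; how this core differs from that of compound 2 is not broken down here. In this assay compound 3 also gives a limit, > 20000 nM. Compound 4 `BrCCCCCOc1nc(/C=C/c2ccccc2)cc(/C=C/c2ccccc2)n1` has not yet been measured. It stands to compound 3 as compound 1 stands to compound 2: bromo in place of bromomethyl on a saturated chain carbon, five bonds along the chain from an oxygen on an aromatic ring. The surroundings are not identical, since the place is five bonds along the chain from the oxygen here against four bonds there, so it is the same kind of change, not the same one.

For compound 4 in this assay the expected value is 40000 nM, most likely again a limit rather than a number. The expected step, a step that the limit leaves unreadable from compound 3 to compound 4, rests on compound 3 sitting at the limit of > 20000 nM in this assay, at which 3 of the 3 values shown sit, and on the matching pair, compound 1 and compound 2, sitting there too.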

Compound 4, half-maximal inhibitory concentration: > 20000 nM
Compound 4 was reported as a limit (the forecaster's own chance of this, stated with the estimate: 85%); the middle value does not contradict the limit.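

The step from compound 3 to compound 4 cannot be read, and neither can any other step among these compounds, because each value is a limit and not a number: the limit of > 20000 nM in this assay, at which 4 of the 4 values shown sit.

The compounds shown leave open whether changing the length of the bromine-ending chain, on either core, alters the result in this assay at all, since no value here can be read as a number.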